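Series notes: benzyloxy replacing 3-bromophenyl on the exocyclic chain

The compounds below may be only part of what the source reports. "The series", "measured", "known", "first", "only" and "open" are said of these compounds alone.

Measured so far:
compound 1 `Cc1ccc(/C=C2\SC(=O)N(Cc3ccc(C)cc3)C2=O)cc1` — 41.7%
compound 2 `Cc1ccc(CN2C(=O)S/C(=C\c3cccc(Br)c3)C2=O)cc1` — 17.6%

In a functional assay on the whole organism (plasma) with Mus musculus as the target, with a stated time of 15 days, at a dose of 10 mg/kg by the oral route (a lower number here means a weaker effect, a higher number a stronger effect of the compound at the dose given), compound 2 stands lowest of the two, with compound 1 a number 24.1 percentage points lower from compound 1 to compound 2 (beyond the scatter). Compound 3 `Cc1ccc(CN2C(=O)S/C(=C\OCc3ccccc3)C2=O)cc1` is not yet measured; its change from compound 2 is benzyloxy in place of 3-bromophenyl on a double-bonded chain carbon bound to a double-bonded ring carbon. Among the measured compounds shown here, only the step from compound 1 to compound 2 bears on it, and it concerns a different group at the same place, so it shows no more than that this position moves the number. The step of a number 7.4 percentage points higher from compound 2 to compound 3 (within the scatter) is therefore expected to stay within the scatter, with a wide range. Compound 3 is estimated at 25%, between 5% and 50%.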

Compound 3, a percentage reported as activity, at one dose (the size of the read-out at that dose, not a potency): 43.6%
Compound 3: the middle estimate sits 18.6 percentage points below what was measured, within the range that was stated.
By their numbers in this assay, from the lowest: compound 2; then compounds 1 and 3 (each within the scatter of the next).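

In this assay, benzyloxy in place of 3-bromophenyl gives a number 26 percentage points higher from compound 2 to compound 3 (beyond the scatter) and so shows that this position can carry a group other than a directly attached aromatic ring. Benzyloxy in place of 4-methylphenyl gives a number 1.9 percentage points higher from compound 1 to compound 3 (within the scatter) and leaves compound 2 as the low one of the three. Nothing available explains the difference between these groups.

Going by these compounds, whether the bromine or the 3-bromophenyl pattern sets compound 2 apart remains open. So does the outcome with an amine, a carboxylic acid or a longer chain at this place.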